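Replacing 4-(tert-butyl)phenyl with 1-benzothiophen-2-yl on a sulfonamide nitrogen

This account rests on a few compounds, and the source may have more. Where it says the series, first, only, none or still open, it means among the compounds named here.

In a physicochemical assay for lipophilicity, at pH 7.4 (a higher number here means a more lipophilic compound, a lower number a more polar compound), compound 3 `CC(C)CN(c1ccc(C(C)(C)C)cc1)S(=O)(=O)c1ccc2c(c1)C(=O)CC(C1CCOCC1)O2` gives 4.97, the highest of the three measured numbers, above compound 1 `CC(C)CN(C1CCc2ccc(F)cc21)S(=O)(=O)c1ccc2c(c1)C(=O)CC(C1CCOCC1)O2` at 4.03 and compound 2 `CC(C)CN(c1ccc(C#N)cc1)S(=O)(=O)c1ccc2c(c1)C(=O)CC(C1CCOCC1)O2` at 3.16. Compound 4 `CC(C)CN(c1cc2ccccc2s1)S(=O)(=O)c1ccc2c(c1)C(=O)CC(C1CCOCC1)O2` carries 1-benzothiophen-2-yl in place of 4-(tert-butyl)phenyl on a sulfonamide nitrogen. Two modest steps at this nitrogen bear on it, a number 0.94 log units higher from compound 1 to compound 3 (beyond the scatter) and a number 0.87 log units lower from compound 1 to compound 2 (beyond the scatter), while the large a number 1.81 log units higher from compound 2 to compound 3 (beyond the scatter) shows how far one substituent change can move this assay. Within the data shown here, no measured compound carries the entering group, and compound 3 stands at the top of the series. A modest fall is therefore expected, an estimated a number 0.47 log units lower from compound 3 to compound 4 (beyond the scatter). Compound 4 is estimated at 4.5, within a range of 4.1 to 4.9.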

Compound 4, distribution coefficient: 4.01
For compound 4 the middle estimate is 0.49 log units above the measured one, and the stated range ends above it.
By their numbers in this assay, from the lowest: compound 2; then compounds 4 and 1 (each within the scatter of the next); then compound 3.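

In this assay the 1-benzothiophen-2-yl group on the sulfonamide nitrogen gives a number 0.96 log units lower from compound 3 to compound 4 (beyond the scatter) and also a number 0.85 log units higher from compound 2 to compound 4 (beyond the scatter) so it falls inside the range already set by the earlier groups, with neither end extended. Against 6-fluoro-2,3-dihydro-1H-inden-1-yl the new group reads the same, with a number 0.02 log units lower from compound 1 to compound 4 (within the scatter) so two quite different groups here cannot be told apart. No measurement shown here accounts for these differences. Still open, going by these compounds, is how a plain thiophene or a pyridine would read on this nitrogen, and what an amine or a carboxylic acid on the aromatic group would do.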